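The source may hold more compounds than are shown below. What is called first, only, known or untested is meant among the compounds shown, and "the series" means these compounds.

In a functional assay on MDA-MB-231 cells (Homo sapiens) for antiproliferative activity, read by MTT assay, with a stated time of 72 h (on this read-out higher numbers stand for weaker inhibition and lower numbers for stronger inhibition), compound 3, `COc1cccc(NC(=O)Nc2cccc(-c3nc(-c4ccc(NC(=O)c5cccnc5)cc4Cl)no3)c2)c1`, is the only one of the three measured compounds that returns a number, giving 6700 nM. Compound 1, `O=C(Nc1ccc(-c2noc(-c3cccc(NS(=O)(=O)c4cccc(Cl)c4)c3)n2)c(Cl)c1)c1cccnc1`, sits at the assay limit of > 10000 nM, which is a limit and not a number. Compound 2, `Cc1ccc(S(=O)(=O)Nc2cccc(-c3nc(-c4ccc(NC(=O)c5cccnc5)cc4Cl)no3)c2)cc1`, likewise sits at a limit, giving > 10000 nM. The steps that run toward compound 3 are therefore only floors: an at least 1.4-fold lower number from compound 1 to compound 3 (0.17 log units; that floor lies within the scatter) and an at least 1.4-fold lower number from compound 2 to compound 3 (0.17 log units; that floor lies within the scatter), both resting on (the limit of > 10000 nM in this assay, at which 2 of the 3 values shown sit), while a step that the two limits leave unreadable from compound 1 to compound 2.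

Compound 4, `CS(=O)(=O)Nc1ccc(NC(=O)Nc2cccc(-c3nc(-c4ccc(NC(=O)c5cccnc5)cc4Cl)no3)c2)cc1Br`, is not yet measured. It differs from compound 3 by 3-bromo-4-(methanesulfonamido)phenyl in place of 3-methoxyphenyl on an amide-type nitrogen. For the measured compounds named here, none of the measured steps alters this part of the structure, so they give no direct reading of the change; the only footing is the value of compound 3 itself. Compound 4 is therefore expected to sit near compound 3, with a 1.1-fold lower number from compound 3 to compound 4 (0.05 log units; within the scatter) lying within the scatter. The estimate for compound 4 in this assay is 6000 nM, within a range of 2500 nM to 15000 nM.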

Compound 4, half-maximal inhibitory concentration: 700 nM
Beside the measured number, compound 4's estimate is 8.6-fold (0.93 log units) above it, outside the stated range (below it).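

In this assay, placing 3-bromo-4-(methanesulfonamido)phenyl instead of 3-methoxyphenyl on the amide-type nitrogen gives a 9.6-fold lower number from compound 3 to compound 4 (0.98 log units; beyond the scatter). The step lies beyond the scatter, so the aryl group at this position can shift the read-out measurably. It is also the only step here read between two numbers, since the earlier steps gave only floors or could not be read, because compound 1 and compound 2 each rest on a limit: the limit of > 10000 nM in this assay, at which 2 of the 4 values shown sit.

The entering group brings both a bromine and a methanesulfonamido group, and the compounds shown do not divide the step between them. Also open, on these data alone, is how 3-bromophenyl or 4-(methanesulfonamido)phenyl alone would read on this nitrogen, and whether an amine or a carboxylic acid at that place on the ring would follow compound 4.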